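The source may report more compounds than this note shows. Statements on the series, on what has been measured and on what is new or still open speak of the compounds shown alone.

In a functional assay on HCT-116 cells (Homo sapiens) for inhibition, read by sulforhodamine B assay, with a stated time of 48 h, tested at 50 uM (on this read-out lower numbers stand for less inhibition of growth and higher numbers for more inhibition of growth at the one concentration tested), compound 1 `COc1cc(/C=C/C(=O)/C=C/c2cccs2)ccc1OCc1cn(CCOc2cc(=O)oc3ccccc23)nn1` gives 71%, the highest of the three numbers and beyond the scatter of both others: compound 2 `COc1cc(/C=C/C(=O)/C=C/c2cccc3ccccc23)ccc1OCc1cn(CCCCOc2cc(=O)oc3ccccc23)nn1` gives 56% and compound 3 `COc1cc(/C=C/C(=O)/C=C/c2ccccc2)ccc1OCc1cn(CCCCCOc2cc(=O)oc3ccccc23)nn1` gives 24%. Compound 4 `COc1cc(/C=C/C(=O)/C=C/c2ccccc2)ccc1OCc1cn(CCOc2cc(=O)oc3ccccc23)nn1` differs from compound 1 by one change, (phenyl in place of thiophen-2-yl on a double-bonded chain carbon bound to a double-bonded chain carbon), phenyl in place of thiophen-2-yl on a double-bonded chain carbon bound to a double-bonded chain carbon. Among the measured compounds shown here, no measured pair differs in one place only, so the size of this step is poorly fixed. Compound 3 also carries phenyl, at 24%, but it differs from compound 1 elsewhere as well, so only a modest fall in this assay is expected. The expected step of a number 11 percentage points lower from compound 1 to compound 4 (beyond the scatter) is downward. For compound 4 the estimate is 60%, within 40% to 77%.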

Compound 4, percent growth inhibition at one concentration: 56%
Compound 4: middle estimate off by 4 percentage points, on the high side, and the stated range covers the measured number.
By their numbers in this assay, from the lowest: compound 3; then compounds 2 and 4 (each within the scatter of the next); then compound 1.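

In this assay the change to phenyl at this place gives a number 15 percentage points lower from compound 1 to compound 4 (beyond the scatter), so thiophen-2-yl is favoured over phenyl here, though much of the growth inhibition remains. With phenyl kept, compound 4 gives 56% and compound 3 gives 24% with its longer chain, so the low number of compound 3 cannot be put on phenyl alone.

As far as these compounds go, whether furan-2-yl or a pyridine ring would match thiophen-2-yl here stays open, as does whether thiophen-2-yl keeps its edge on a longer chain. Nothing measured gives a reason for the step.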